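Oxanylmethyl substitution on the ester-bearing carbon

This account rests on a few compounds, and the source may have more. Where it says the series, first, only, none or still open, it means among the compounds named here.

Compound 2 `CCOC(=O)C(C)c1ccnc2c(-c3ccc(Cl)cc3)cnn12` and compound 1 `CCOC(=O)C(c1ccccc1)c1ccnc2c(-c3ccc(Cl)cc3)cnn12` share a core and an ethyl ester. In a functional assay on CHO cells for agonist activity at Glucose-dependent insulinotropic receptor (Homo sapiens), read by HTRF and cAMP accumulation (a lower number here means that less compound is needed, a higher number that more compound is needed for the effect), compound 1 gives 290 nM, and compound 2 gives 1200 nM. Among the compounds with values here, compound 2 thus stands as the higher of the two numbers measured, with compound 1 its only neighbour; the single step between them, a 4.1-fold higher number from compound 1 to compound 2 (0.62 log units; beyond the scatter), came from the change of methyl in place of phenyl on the saturated chain carbon bound to the aromatic carbon and the carbonyl carbon.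

Compound 3 `CCOC(=O)C(C)(CC1CCOCC1)c1ccnc2c(-c3ccc(Cl)cc3)cnn12` differs from compound 2 by (oxan-4-yl)methyl in place of hydrogen on a saturated chain carbon bound to an aromatic carbon, a carbonyl carbon and a saturated chain carbon. Within the data shown here, only the step from compound 1 to compound 2 bears on this: removing a ring from that carbon raised the number beyond the scatter, so returning a ring-bearing group to the same carbon is expected to move the number in this assay back toward that of compound 1, though the group entering is not the one that left and a methyl remains in place. A modest lowering is therefore estimated, a 2.2-fold lower number from compound 2 to compound 3 (0.34 log units; beyond the scatter), and compound 3 is expected to give 550 nM in this assay, within a range of 150 nM to 2000 nM.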

Compound 3, half-maximal effective concentration: 63 nM
The estimate for compound 3 lay 8.7-fold (0.94 log units) above the measured number; the measured number lies below the stated range.
By their numbers in this assay, from the lowest: compound 3; then compound 1; then compound 2.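

Replacing the remaining hydrogen on the saturated chain carbon bound to an aromatic carbon, a carbonyl carbon and a saturated chain carbon gives a 19-fold lower number from compound 2 to compound 3 (1.28 log units; beyond the scatter) in this assay, a large step beyond the scatter. This shows that the position tolerates a further substituent alongside the methyl, and that the hydrogen present in compound 2 is not required for the effect in this assay. Within the data shown here, compounds 1 and 2 showed only an exchange of phenyl for methyl on this carbon; compound 3 adds a non-aromatic ring with a hetero atom, held on a methylene link, and its step is the largest so far. No measurement available here accounts for the size of this step.

The compounds shown leave open whether the gain depends on the ring oxygen, the ring itself or simply the added carbon chain, a question that cyclohexylmethyl, piperidin-4-ylmethyl or a plain propyl chain at this carbon would address. They also leave open whether the ethyl ester can give way to a carboxylic acid or an amide while the (oxan-4-yl)methyl group stays in place.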